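A few compounds are considered here, and "the series" means these few. Any claim that something is new, unique, unknown or untested is made for them only; others in the source may bear on it.

Of the compounds shown here, three sharing one core have been tested in a functional assay on MDA-MB-435 cells (Homo sapiens) for cytotoxicity, read by MTT assay, with a stated time of 72 h; a lower number here means a stronger inhibitor, a higher number a weaker inhibitor. Among the compounds with values here, compound 2 `CN(C)CCCNc1c(C(=O)NCc2ccc(F)cc2)nc(Br)c2cccnc12`, which carries a (3-(dimethylamino)propyl)amino group, gives 7000 nM, the only actual number in the set. Compound 1 `CS(=O)(=O)Oc1c(C(=O)NCc2ccc(F)cc2)nc(Br)c2cccnc12` reads > 20000 nM, which is a limit of the assay and not a number. Compound 3 `O=C(NCCCNc1c(C(=O)NCc2ccc(F)cc2)nc(Br)c2cccnc12)c1ccccc1` reads > 20000 nM, which is also a limit. The remaining data therefore stand at the limit of > 20000 nM in this assay, at which 2 of the 3 values shown sit.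

Compound 4 `O=C(NCc1ccc(F)cc1)c1nc(Br)c2cccnc2c1N1CCNCC1` changes compound 2 at one place, with piperazin-1-yl in place of (3-(dimethylamino)propyl)amino on an aromatic carbon.

Within the data shown here, two measured steps bear on this change, and each is at least modest. One is an at least 2.8-fold lower number from compound 1 to compound 2 (0.45 log units; beyond the scatter), where the amine chain replaces the (methylsulfonyl)oxy group at this same carbon. The other is an at least 2.8-fold higher number from compound 2 to compound 3 (0.45 log units; beyond the scatter), where benzamido takes the place of dimethylamino at the chain end. Compound 4 has an amine group at that carbon and no benzamido, so neither step points to a loss of the measurable value. Among the measured compounds shown here, no measured step swaps the chain for a ring, so the expectation remains loose.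

The expected size is a 1.3-fold higher number from compound 2 to compound 4 (0.11 log units; within the scatter), which would be no step beyond the scatter. Compound 4 is estimated at 9000 nM, with an expected range of 3500 nM to 20000 nM.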

Compound 4, half-maximal inhibitory concentration: 8000 nM
Estimate against measurement, compound 4: 1.1-fold (0.05 log units) above; measured number inside the range.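

In this assay, the exchange of the open (3-(dimethylamino)propyl)amino chain for the piperazin-1-yl ring on this aromatic carbon is a 1.1-fold higher number from compound 2 to compound 4 (0.06 log units; within the scatter), so the two groups cannot be told apart here. The earlier compounds shown here showed only that one amine chain at this carbon gave a measurable value where (methylsulfonyl)oxy did not, and the new result shows that an open chain is not required for this: an at least 2.5-fold lower number from compound 1 to compound 4 (0.39 log units; beyond the scatter) stands alongside the earlier at least 2.8-fold lower number from compound 1 to compound 2 (0.45 log units; beyond the scatter). Both steps start from compound 1, whose reading is a limit of the assay and not a number, so they give only a smallest possible size.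

Going by these compounds, it remains open whether a morpholine ring, a piperazine with a methyl group on its free nitrogen, or a shorter or longer amine chain at this carbon would read differently from compound 2 and compound 4. The upper end of the set also stays unresolved: the limit of > 20000 nM in this assay, at which 2 of the 4 values shown sit.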